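The source may report more compounds than this note shows. Statements on the series, on what has been measured and on what is new or still open speak of the compounds shown alone.

Measured so far in a physicochemical assay for solubility, read by HPLC (a lower number here means a less soluble compound, a higher number a more soluble compound), for this series:
- compound 1 `COc1ccc(NC[C@H](O)COc2ccc(N3C[C@H](CNC(C)=O)OC3=O)cc2F)cc1` gives 56000 nM in this read-out
- compound 2 `CC(=O)NC[C@H]1CN(c2ccc(OC[C@@H](O)CNc3cccnc3)c(F)c2)C(=O)O1` gives 3040000 nM in this read-out

Compound 2 holds the higher of the two numbers. Going by the values given here, the only measured step, with pyridin-3-yl in place of 4-methoxyphenyl on an amine nitrogen, is a 54-fold higher number from compound 1 to compound 2 (1.73 log units; beyond the scatter) and counts as large.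

Compound 3 `CC(=O)NC[C@H]1CN(c2ccc(OC[C@H](O)CNCCC(C)C)c(F)c2)C(=O)O1` carries 1-hydroxy-2-(isopentylamino)ethyl in place of 1-hydroxy-2-((pyridin-3-yl)amino)ethyl on a saturated chain carbon bound to an oxygen on an aromatic ring, and the entering group has no ring.

That single step bears on this change, as it also replaced the group on the amine nitrogen. It shows that a swap there can move the number in this assay a long way. Among the compounds with values here, no measured compound has an open chain on that nitrogen, so the direction rests on little. Within the data shown here, compound 2 at 3040000 nM tops only two values, so a lower number is expected for compound 3, by less than the measured step. The expected move is a 3.0-fold lower number from compound 2 to compound 3 (0.48 log units; beyond the scatter) and the range stays wide. Compound 3 is estimated at 1000000 nM (expected range 200000 nM to 4000000 nM).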

Compound 3, solubility: 7280000 nM
Beside the measured number, compound 3's estimate is 7.3-fold (0.86 log units) below it; the measured number lies above the stated range.
By their numbers in this assay, from the lowest: compound 1; then compound 2; then compound 3.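

In this assay, 1-hydroxy-2-(isopentylamino)ethyl in place of 1-hydroxy-2-((pyridin-3-yl)amino)ethyl on a saturated chain carbon bound to an oxygen on an aromatic ring gives a 2.4-fold higher number from compound 2 to compound 3 (0.38 log units; beyond the scatter) as a modest step, so the pyridin-3-yl compound no longer holds the top number. Compound 3, whose entering group has no ring, now stands highest of the three, which shows that an aromatic ring on the amine nitrogen is not needed for a high number in this assay within this small set. Both measured steps at this nitrogen raise the number, the earlier one being a 54-fold higher number from compound 1 to compound 2 (1.73 log units; beyond the scatter) and clearly the larger, and nothing at hand explains either rise.

As far as these compounds go, it remains open whether the latest rise goes with the branching of the isopentyl chain, its length, or the loss of the ring; a straight pentyl chain, a shorter ethyl chain and a cyclohexyl group on that nitrogen would separate these readings. Also open, from the compounds shown here alone, is how the number responds to a carboxylic acid or a morpholine at the end of the chain.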